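The compounds below may be only part of what the source reports. "The series", "measured", "known", "first", "only" and "open" are said of these compounds alone.

In a functional assay on Mahlavu cells (Homo sapiens) for antiproliferative activity, read by sulforhodamine B assay, with a stated time of 72 h (a higher number here means a weaker inhibitor, a lower number a stronger inhibitor), compound 1 `FC(F)(F)c1ccc(CN2CCN(Cc3cc(-c4ccc(OCc5ccccc5)cc4)on3)CC2)cc1` gives 11700 nM, compound 2 `FC(F)(F)c1ccc(CN2CCN(Cc3cc(-c4ccc(OCc5cccc(Cl)c5)cc4)on3)CC2)cc1` gives 4100 nM, and compound 3 `Fc1cccc(COc2ccc(-c3cc(CN4CCN(Cc5ccc(C(F)(F)F)cc5)CC4)no3)cc2)c1` gives 2900 nM, the lowest of the three numbers. The step of a 4.0-fold lower number from compound 1 to compound 3 (0.61 log units; beyond the scatter) lies beyond the scatter, whereas the step of a 1.4-fold lower number from compound 2 to compound 3 (0.15 log units; within the scatter) does not, so compound 3 and compound 2 cannot be ranked against each other. Compound 4 `COc1cc(COc2ccc(-c3cc(CN4CCN(Cc5ccc(C(F)(F)F)cc5)CC4)no3)cc2)cc(OC)c1` carries 3,5-dimethoxyphenyl in place of 3-fluorophenyl on a saturated chain carbon bound to an oxygen on an aromatic ring. The measured steps, a 2.9-fold lower number from compound 1 to compound 2 (0.46 log units; beyond the scatter) and a 4.0-fold lower number from compound 1 to compound 3 (0.61 log units; beyond the scatter), each add a single halogen to the unsubstituted ring; none covers methoxy groups, and in compound 4 the fluorine is gone. The number for compound 4 is therefore expected to climb part of the way back, an expected step of a 1.9-fold higher number from compound 3 to compound 4 (0.28 log units; within the scatter). Compound 4 is estimated at 5500 nM, with a range from 2000 nM to 15000 nM.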

Compound 4, half-maximal inhibitory concentration: 4300 nM
Compound 4: middle estimate off by 1.3-fold (0.11 log units), on the high side, within the range that was stated.
By their numbers in this assay, from the lowest: compounds 3, 2 and 4 (each within the scatter of the next); then compound 1.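

Halogen is not required at this position: in this assay the 3,5-dimethoxyphenyl group shows a 1.5-fold higher number from compound 3 to compound 4 (0.17 log units; within the scatter) and a 1.0-fold higher number from compound 2 to compound 4 (0.02 log units; within the scatter), so it cannot be separated from either halogenated ring. It still keeps a 2.7-fold lower number from compound 1 to compound 4 (0.43 log units; beyond the scatter), so among these compounds fluoro, chloro and dimethoxy substitution all give lower numbers than plain phenyl. No measurement here explains why these different groups give such similar numbers. As far as these compounds go, whether a ring carrying an amine or a carboxylic acid would follow this pattern remains open.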